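The compounds below may be only part of what the source reports. "The series", "measured", "known", "first", "only" and "open" are said of these compounds alone.

Measured so far:
compound 1 `COc1ccc2nc(N(Cc3cc(-c4ccccc4F)no3)c3nc4ccc(F)cc4s3)sc2c1` — 51800 nM
compound 2 `FC(F)(F)Sc1ccc(-c2cc(CN(c3ncccn3)c3nc4ccccc4s3)on2)cc1` — 29800 nM

Both numbers come from a functional assay on A549 cells (Homo sapiens) for antiproliferative activity, read by MTT assay; on this read-out higher numbers stand for weaker inhibition and lower numbers for stronger inhibition. Compound 2 gives 29800 nM and compound 1 gives 51800 nM; compound 2 carries the lower of the two numbers, but the gap to compound 1 is within the scatter, so the two cannot be ordered, and the two structures also differ in more than one place, so no single step can be read from them.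

Compound 3 `FC(F)(F)Oc1ccc(-c2cc(CN(c3ncccn3)c3nc4ccccc4s3)on2)cc1` is not yet measured. It differs from compound 2 by trifluoromethoxy in place of (trifluoromethyl)sulfanyl on an aromatic carbon. The change swaps one group of five heavy atoms for another of the same size, both without a ring, each with one hydrogen-bond acceptor and no donor, on the same aromatic carbon. Within the data shown here, no measured pair isolates this change, so its effect is not known here. The working expectation is that compound 3 stays near compound 2, with the step from compound 2 to compound 3 estimated as a 1.2-fold higher number from compound 2 to compound 3 (0.07 log units; within the scatter), not beyond the scatter in either direction. Compound 3 is therefore estimated at 35000 nM in this assay, with a range from 12000 nM to 100000 nM.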

Compound 3, half-maximal inhibitory concentration: 31800 nM
For compound 3 the middle estimate is 1.1-fold (0.04 log units) above the measured one; low and high end bracket the measured number.
By their numbers in this assay, from the lowest: compounds 2, 3 and 1 (each within the scatter of the next).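

In this assay, among these compounds, the exchange on an aromatic carbon para to a large group gives a 1.1-fold higher number from compound 2 to compound 3 (0.03 log units; within the scatter), and this is the first comparison that isolates a single change. On this pair, trifluoromethoxy and (trifluoromethyl)sulfanyl cannot be told apart at this position, so the 4-((trifluoromethyl)sulfanyl)phenyl to 4-(trifluoromethoxy)phenyl change leaves the number within the scatter, although a single pair supports no wider rule. No measurement on hand bears on why the two groups read alike.

Going by these compounds, both groups are of equal heavy-atom count, without a ring and uncharged, so it remains open how far the read-out at this position responds to a group of a different kind, such as an amine, a carboxylic acid or a longer alkyl chain. On these data alone, it is also open whether the same exchange would read alike on a different scaffold such as the core of compound 1, which differs from compound 2 and compound 3 in more than one place.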